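A few compounds are considered here, and "the series" means these few. Any claim that something is new, unique, unknown or untested is made for them only; others in the source may bear on it.

Measured so far in a functional assay (muscle tissue) with Cavia porcellus as the target; a lower number here means that less compound is needed, a higher number that more compound is needed for the effect:
compound 1 `COC(=O)C1=C(C)N=C(C)/C(=C(\O)OC)C1c1ccccc1N` gives 39800 nM
compound 2 `COC(=O)C1=C(C)N=C(C)/C(=C(\O)OC)C1c1cccc(Cl)c1Cl` gives 19.1 nM
compound 3 `COC(=O)C1=C(C)N=C(C)/C(=C(\O)OC)C1c1ccc(Cl)cc1Cl` gives 640 nM

Compound 3 stands second highest of the three numbers; the nearest is compound 2, reached by a 34-fold higher number from compound 2 to compound 3 (1.53 log units; beyond the scatter), the furthest is compound 1, as in a 62-fold lower number from compound 1 to compound 3 (1.79 log units; beyond the scatter). Compound 4 `COC(=O)C1=C(C)N=C(C)/C(=C(\O)OC)C1c1ccc(C#N)cc1` differs from compound 3 in one place: 4-cyanophenyl in place of 2,4-dichlorophenyl on a saturated ring carbon. Going by the values given here, no measured step makes this exact exchange. Among the compounds with values here, the steps that bear on it all alter the substituents on that phenyl, and each was large: a 2100-fold lower number from compound 1 to compound 2 (3.32 log units; beyond the scatter), a 62-fold lower number from compound 1 to compound 3 (1.79 log units; beyond the scatter), a 34-fold higher number from compound 2 to compound 3 (1.53 log units; beyond the scatter). Within this set, the substituents on the phenyl move the number in this assay strongly, so a large step is expected here as well, toward a higher number, with wide uncertainty. Compound 4 is estimated at 3000 nM, range 600 nM to 15000 nM, meaning an expected 4.7-fold higher number from compound 3 to compound 4 (0.67 log units; beyond the scatter).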

Compound 4, half-maximal effective concentration: 3470 nM
Estimate against measurement, compound 4: 1.2-fold (0.06 log units) below, within the range that was stated.
By their numbers in this assay, from the lowest: compound 2; then compound 3; then compound 4; then compound 1.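

In this assay, replacing the 2,4-dichlorophenyl with 4-cyanophenyl on the saturated ring carbon gives a 5.4-fold higher number from compound 3 to compound 4 (0.73 log units; beyond the scatter) and so costs far less than the range across this position. Compound 4 has no substituent at the 2 position of the phenyl, yet an 11-fold lower number from compound 1 to compound 4 (1.06 log units; beyond the scatter) shows that such a substituent is not needed to beat the 2-aminophenyl. The 2,3-dichlorophenyl stays well ahead, with a 180-fold higher number from compound 2 to compound 4 (2.26 log units; beyond the scatter) as the gap. No supporting data explain these steps. Going by these compounds, it remains open whether the nitrile or the loss of both chlorines sets the step, and how a 4-chlorophenyl or a 4-carboxyphenyl would read.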